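Replacing an aryl amide with a benzyl urea at the chemokine receptor

The source may report more compounds than this note shows. Statements on the series, on what has been measured and on what is new or still open speak of the compounds shown alone.

Measured so far:
compound 1, `CC[C@@H](NC(=O)CC(C)C)C(=O)N1CCC(c2ccc(Cl)cc2)CC1`, 152 nM
compound 2, `Cc1ccc(C(=O)N[C@@H](C(=O)N2CCC(c3ccc(Cl)cc3)CC2)C(C)C)cc1`, 25 nM
compound 3, `CC[C@@H](C)[C@@H](NC(=O)c1ccccc1)C(=O)N1CCC(c2ccc(Cl)cc2)CC1`, 45 nM

All three compounds share the same core and were tested in an assay on THP-1 cells for displacement of a labelled ligand from C-C chemokine receptor type 1 (Homo sapiens); on this read-out higher numbers stand for weaker inhibition and lower numbers for stronger inhibition. Compound 2 gives the lowest number of the three, 25 nM. Its neighbour is compound 3 at 45 nM; this gap lies within the scatter, so the two cannot be ranked against each other. Compound 1, at 152 nM, sits beyond the scatter from compound 2 and so is clearly the weaker binder of that pair.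

Compound 4, `CC(C)[C@@H](NC(=O)NCc1ccccc1)C(=O)N1CCC(c2ccc(Cl)cc2)CC1`, is not yet measured. It differs from compound 2 in one place: benzylamino in place of 4-methylphenyl on a carbonyl carbon. The carbonyl carbon that carried an aromatic ring now carries a nitrogen bearing a hydrogen, which in turn carries the ring.

For the measured compounds named here, no measured pair shows this kind of exchange, so the size of the step is uncertain. Since compounds 2 and 3, both with an aromatic ring directly on the carbonyl, give the lower numbers, while compound 1 without such a ring gives 152 nM, a moderate loss is expected, though the retained ring may keep the loss small. The step from compound 2 to compound 4 is expected to be a 2.4-fold higher number from compound 2 to compound 4 (0.38 log units; beyond the scatter). Compound 4 is thus estimated at 60 nM, between 15 nM and 250 nM.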

Compound 4, half-maximal inhibitory concentration: 180 nM
For compound 4 the middle estimate is 3.0-fold (0.48 log units) below the measured one, within the range that was stated.
By their numbers in this assay, from the lowest: compounds 2 and 3 (each within the scatter of the next); then compounds 1 and 4 (each within the scatter of the next).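

In this assay, putting benzylamino in place of 4-methylphenyl on a carbonyl carbon gives a 7.2-fold higher number from compound 2 to compound 4 (0.86 log units; beyond the scatter), a loss larger than the usual scatter of the measurement. An aromatic ring of carbon only stands on both sides of this step, so at this position the presence of such a ring does not by itself hold the number; how the ring is attached to the carbonyl carbon, or the methyl group it carries, also matters. The step changes several things at once: the entering group brings a nitrogen with a hydrogen-bond donor and a carbon link to the ring, and it lacks the methyl group, while no measurement here gives a reason for the loss.

The compounds shown leave open which of these differences accounts for the higher number. A phenylamino group on the same carbonyl carbon would keep the nitrogen without the carbon link, a benzyl group would keep the carbon link without the nitrogen, and a 4-methylbenzylamino group would restore the methyl group, so each would help separate these effects.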